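The compounds below may be only part of what the source reports. "The series", "measured", "known", "first", "only" and "open" are said of these compounds alone.

Compound 1 `COc1cc(OC)nc(N2C(=O)CSC2c2c(Cl)cccc2Cl)n1` and compound 3 `COc1cc(OC)nc(N2C(=O)CSC2c2c(F)cccc2Cl)n1` share one core, while compound 2 `O=C1CSC(c2c(F)cccc2Cl)N1c1ccccn1` and compound 4 `O=C1CSC(c2c(F)cccc2F)N1c1ccccn1` share another; the difference between the two cores is not broken down here. In an ADME assay on TZM cells (Homo sapiens) for cytotoxicity, read by MTT assay, with a stated time of 48 h (a higher number here means that more compound is tolerated, a lower number that less compound is tolerated), compound 1 gives 85400 nM, compound 3 gives 98200 nM, and compound 2 gives 153000 nM. The change from compound 1 to compound 3 is fluoro in place of chloro on an aromatic carbon, and it made a 1.1-fold higher number from compound 1 to compound 3 (0.06 log units; within the scatter). Compound 4 carries the same kind of change, (fluoro in place of chloro on an aromatic carbon); the only difference in the surroundings is that here the place is meta to a fluoro group rather than meta to a chloro group. Because a 1.1-fold higher number from compound 1 to compound 3 (0.06 log units; within the scatter) lay within the scatter, compound 4 is expected to show only a small step, a 1.1-fold higher number from compound 2 to compound 4 (0.05 log units; within the scatter). Compound 4 is therefore estimated at 170000 nM, with a likely range from 90000 nM to 320000 nM.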

Compound 4, half-maximal cytotoxic concentration: 90100 nM
Compound 4: middle estimate off by 1.9-fold (0.28 log units), on the high side, and the stated range covers the measured number.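

In this assay, the swap of chloro for fluoro on the second core gives a 1.7-fold lower number from compound 2 to compound 4 (0.23 log units; within the scatter). Set beside the same swap on the first core, this step does not differ from it by more than repeated measurements would: the same change on two cores in this assay, a 1.1-fold higher number (0.06 log units; within the scatter) from compound 1 to compound 3 and a 1.7-fold lower number (0.23 log units; within the scatter) from compound 2 to compound 4, 2.0-fold (0.29 log units) apart, within the scatter of two such steps So on these two cores the change leaves the tolerated concentration within the scatter, but two pairs cannot show that it would behave alike on every core, and a small true difference between the cores could stay hidden in the scatter.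

The compounds shown carry only chloro or fluoro in this place on the aromatic ring. Going by these compounds, whether an amine or a carboxylic acid there would shift the number beyond the scatter stays open.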